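The source may report more compounds than this note shows. Statements on the series, on what has been measured and on what is new or still open speak of the compounds shown alone.

Measured so far in a functional assay on KBVIN cells (Homo sapiens) for antiproliferative activity, read by sulforhodamine B assay, with a stated time of 3 days; a higher number here means that more compound is needed for the effect, a lower number that less compound is needed:
compound 1 `CCC1=C(O)c2c(oc(-c3ccc(CC)cc3)cc2=O)C(CC)(CC)C1=O`: 0.07 uM
compound 2 `CCC1=C(O)c2c(oc(-c3ccc(C(C)C)cc3)cc2=O)C(CC)(CC)C1=O`: 1.08 uM
compound 3 `CCC1=C(O)c2c(oc(-c3ccc(OC)cc3)cc2=O)C(CC)(CC)C1=O`: 0.68 uM

Compound 3 stands second highest of the three numbers. Its nearest neighbour is compound 2, with a 1.6-fold lower number from compound 2 to compound 3 (0.20 log units; within the scatter); its furthest is compound 1, with a 9.7-fold higher number from compound 1 to compound 3 (0.99 log units; beyond the scatter).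

Compound 4 `CCC1=C(O)c2c(oc(-c3ccc(COC)cc3)cc2=O)C(CC)(CC)C1=O` differs from compound 3 by methoxymethyl in place of methoxy on an aromatic carbon. Within the data shown here, no measured step converts methoxy to methoxymethyl. The step of a 9.7-fold higher number from compound 1 to compound 3 (0.99 log units; beyond the scatter) shows that exchanging ethyl for methoxy moves the number well beyond the scatter, and a 15-fold higher number from compound 1 to compound 2 (1.19 log units; beyond the scatter) shows that adding a methyl to a chain at this position does so as well, so the position is sensitive. Direction remains unclear. Compound 4 is estimated at 0.5 uM, with a range from 0.12 uM to 2 uM. The expected step is a 1.4-fold lower number from compound 3 to compound 4 (0.13 log units; within the scatter), near the scatter.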

Compound 4, concentration for half-maximal effect: 3.4 uM
Compound 4: the middle estimate sits 6.8-fold (0.83 log units) below what was measured, outside the stated range (above it).
By their numbers in this assay, from the lowest: compound 1; then compounds 3 and 2 (each within the scatter of the next); then compound 4.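

In this assay, methoxymethyl in place of methoxy on the aromatic carbon raises the number beyond the scatter (a 5.0-fold higher number from compound 3 to compound 4 (0.70 log units; beyond the scatter)), and the same holds against isopropyl (a 3.1-fold higher number from compound 2 to compound 4 (0.50 log units; beyond the scatter)). Compound 4 therefore has the highest number of the four, and ethyl remains far ahead of it (a 49-fold higher number from compound 1 to compound 4 (1.69 log units; beyond the scatter)), so this position does not tolerate an oxygen within the chain any better than branching or a directly attached methoxy. Nothing measured here gives a reason for these steps.

From the compounds shown here alone, whether a plain propyl chain would stay close to compound 1 or rise like compound 4 remains open. So does the effect of an aminomethyl group at this place.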